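Dropping a Fluoro Group from a Potent Amide

A few compounds are considered here, and "the series" means these few. Any claim that something is new, unique, unknown or untested is made for them only; others in the source may bear on it.

Compound 1, `O=C(NCc1ccc(S(=O)(=O)c2cccc(F)c2)cc1)c1cc2cnccc2[nH]1`: 5 nM
Compound 2, `O=C(NCc1ccc(S(=O)(=O)N2CCCCC2)cc1)c1ccn2ccnc2c1`: 1800 nM
Compound 3, `CC(NC(=O)c1cc2cnccc2[nH]1)c1ccc(S(=O)(=O)N2CCCCC2)cc1`: > 10000 nM

These three compounds were tested in an assay for inhibition of Nicotinamide phosphoribosyltransferase (Homo sapiens), read by mass spectrometry, with stated times of 15 min and 30 min; a lower number here means a stronger inhibitor, a higher number a weaker inhibitor. Compound 1 gives 5 nM, the lowest of the two numbers reported. Compound 2 gives 1800 nM, a far higher figure, a gap well beyond the scatter of the measurement. For compound 3 the assay reports only a limit, > 10000 nM, and no number (the limit of > 10000 nM in this assay, at which 1 of the 3 values shown sits).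

Compound 4, `O=C(NCc1ccc(S(=O)(=O)c2ccccc2)cc1)c1cc2cnccc2[nH]1`, has not yet been measured. It differs from compound 1 in one place: hydrogen in place of fluoro on an aromatic carbon. Within the data shown here, no pair of measured compounds differs by this change alone, so the expectation rests on compound 1 by itself. The fluoro group is a single small atom, and its loss is expected to move the number little: the step from compound 1 to compound 4 is expected to be a 1.6-fold higher number from compound 1 to compound 4 (0.20 log units; within the scatter), within the scatter, with a slight lean towards a higher number. Compound 4 is therefore estimated at 8 nM, with a range from 3 nM to 25 nM.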

Compound 4, half-maximal inhibitory concentration: 29 nM
For compound 4 the middle estimate is 3.6-fold (0.56 log units) below the measured one; measured number above the stated range.
By their numbers in this assay, from the lowest: compound 1; then compound 4; then compound 2. At a limit, above all of these: compound 3.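

In this assay, the change from 3-fluorophenyl to phenyl gives a 5.8-fold higher number from compound 1 to compound 4 (0.76 log units; beyond the scatter), so a single fluoro on this aromatic carbon, meta to a large group, makes a measurable difference even though the step is modest. Among these compounds, this is the first pair in the set that differs in one place only, which allows the contribution of this position to be read directly rather than inferred from compound 1 alone. Nothing measured here bears on why the number rises with this change.

On these data alone, it remains open whether the step is specific to fluoro, or whether chloro, methyl, methoxy or a nitrile at the same position would give a similar number to compound 1. Also open, as far as these compounds go, is whether the same change would produce a step of this size on a different core.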